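Closing the chain into a three-membered ring

A few compounds are considered here, and "the series" means these few. Any claim that something is new, unique, unknown or untested is made for them only; others in the source may bear on it.

This account follows a series of analogues sharing one core, varied only on a saturated chain carbon bound to an aromatic nitrogen. Compound 1 `CCCn1c(Cc2cc(OC)c(OC)c(OC)c2)nc2c(N)ncnc21` carries a propyl chain there and in a functional assay on MCF7 cells (Homo sapiens) for antiproliferative activity (a higher number here means a weaker inhibitor, a lower number a stronger inhibitor), gives 46800 nM. Compound 2 `CC/C=C/Cn1c(Cc2cc(OC)c(OC)c(OC)c2)nc2c(N)ncnc21` gives 46800 nM in this assay, and compound 3 `COc1cc(Cc2nc3c(N)ncnc3n2CC2CCC2)cc(OC)c1OC` gives 45700 nM in this assay. Compound 1 thus sits level with compound 2, the two together at the high end of three numbers, with compound 3 within scatter of both: no change at the digits printed from compound 1 to compound 2 (within the scatter) and a 1.0-fold lower number from compound 1 to compound 3 (0.01 log units; within the scatter), while a 1.0-fold lower number from compound 2 to compound 3 (0.01 log units; within the scatter).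

Compound 4 `COc1cc(Cc2nc3c(N)ncnc3n2CC2CC2)cc(OC)c1OC` has not yet been measured. It differs from compound 1 as follows: cyclopropyl in place of ethyl on a saturated chain carbon bound to an aromatic nitrogen. The step that bears on it most directly is the one with cyclobutyl in place of ethyl at the same place, a 1.0-fold lower number from compound 1 to compound 3 (0.01 log units; within the scatter), which lay within the scatter. On that basis no step beyond the scatter is expected for cyclopropyl in place of ethyl, so a 1.0-fold lower number from compound 1 to compound 4 (0.01 log units; within the scatter) is the expected outcome. Compound 4 is therefore estimated at 46000 nM in this assay, within a range from 23000 nM to 92000 nM.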

Compound 4, half-maximal inhibitory concentration: 75900 nM
Compound 4: middle estimate off by 1.7-fold (0.22 log units), on the low side, and the stated range covers the measured number.
By their numbers in this assay, from the lowest: compounds 3, 1, 2 and 4 (each within the scatter of the next).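

With the chain closed into a three-membered ring, this assay still shows no step beyond the scatter at this position (a 1.6-fold higher number from compound 1 to compound 4 (0.21 log units; within the scatter)), and the same holds against the larger ring (a 1.7-fold higher number from compound 3 to compound 4 (0.22 log units; within the scatter)) and against the unsaturated chain (a 1.6-fold higher number from compound 2 to compound 4 (0.21 log units; within the scatter)). Across compounds 1 to 4, then, ethyl, but-1-en-1-yl, cyclobutyl and cyclopropyl on a saturated chain carbon bound to an aromatic nitrogen cannot be told apart in this read-out, so a three-membered ring adds no separation that the earlier compounds lacked. Nothing available bears on why these numbers stand as they do.

From the compounds shown here alone, all four groups are built of carbon alone, so an amine, a hydroxyl or a carboxylic acid at this place remains untested here. Going by these compounds, whether a phenyl ring or a much longer chain there would give a step beyond the scatter also stays open.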